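Replacing cyclohexyl with piperidin-1-yl on a shared core

This account rests on a few compounds, and the source may have more. Where it says the series, first, only, none or still open, it means among the compounds named here.

Values in a functional assay on C6 cells (Rattus norvegicus) for inhibition, read by sulforhodamine B assay, with a stated time of 72 h; on this read-out higher numbers stand for an effect only at larger amounts of compound and lower numbers for an effect already at smaller amounts:
compound 1 `CSc1ccc(C(=O)/C=C/c2ccc([N+](=O)[O-])o2)cc1`: 1600 nM
compound 2 `O=C(/C=C/c1ccc([N+](=O)[O-])o1)c1ccc(C2CCCCC2)cc1`: 5100 nM
compound 3 `O=C(/C=C/c1ccc([N+](=O)[O-])o1)c1ccc(N2CCCCC2)cc1`: not yet measured

Going by the values given here, compound 2 at 5100 nM has the higher of the two numbers, and compound 1 is its only neighbour. The next compound, compound 3, carries piperidin-1-yl in place of cyclohexyl on an aromatic carbon. Among the compounds with values here, one measured step bears on this place: a 3.2-fold higher number from compound 1 to compound 2 (0.50 log units; beyond the scatter) is modest and beyond the scatter, with cyclohexyl in place of methylsulfanyl. Within the data shown here, no measurement yet tests piperidin-1-yl, so that step offers only a rough guide to size. With cyclohexyl leaving, a small move towards a lower number is expected in this assay and may stay within the scatter. The expected step is a 1.7-fold lower number from compound 2 to compound 3 (0.23 log units; within the scatter) and it should be no larger than the measured one. Compound 3 is estimated at 3000 nM with 1200 nM to 7500 nM as the expected range.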

Compound 3, half-maximal effective concentration: 48700 nM
Estimate against measurement, compound 3: 16-fold (1.21 log units) below, and the stated range ends below it.
By their numbers in this assay, from the lowest: compound 1; then compound 2; then compound 3.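

In this assay, the aromatic carbon para to a large group proves sensitive to a change within the ring itself. Piperidin-1-yl keeps the six-membered non-aromatic ring and the heavy-atom count of cyclohexyl, with nitrogen in place of one carbon, yet the change gives a 9.5-fold higher number from compound 2 to compound 3 (0.98 log units; beyond the scatter) in this series, so ring size and heavy-atom count alone do not set the value here. Against methylsulfanyl the same group gives a 30-fold higher number from compound 1 to compound 3 (1.48 log units; beyond the scatter) and thus the highest number of the three compounds. Nothing measured here explains the shift.

The compounds shown leave open whether the ring nitrogen itself drives the step, which morpholin-4-yl or an open-chain diethylamino group at this place could test. They also leave open how a smaller amine, such as pyrrolidin-1-yl, would compare.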